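Moving the fluorine on the benzyloxy group of compound 3

The source may hold more compounds than are shown below. What is called first, only, known or untested is meant among the compounds shown, and "the series" means these compounds.

Measured in a functional assay on a cell-free system (plasma, Oryctolagus cuniculus) for inhibition, with stated times of 5 min, 1 min and 6 min; on this read-out higher numbers stand for weaker inhibition and lower numbers for stronger inhibition:
compound 1 `CCOC(=O)c1c(C)nc(-c2cccc(C#N)c2)n1C`: 22100 nM
compound 2 `C=CCOn1c(-c2cccc(C#N)c2)nc(C)c1C(=O)OCC`: 5860 nM
compound 3 `CCOC(=O)c1c(C)nc(-c2cccc(C#N)c2)n1OCc1ccccc1F`: 8990 nM

Compound 3 sits with compound 2 at the low end of these numbers, and the two cannot be told apart: a 1.5-fold higher number from compound 2 to compound 3 (0.19 log units; within the scatter). Compound 1 stands clearly higher, as a 2.5-fold lower number from compound 1 to compound 3 (0.39 log units; beyond the scatter) shows.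

The next compound to be measured is compound 4 `CCOC(=O)c1c(C)nc(-c2cccc(C#N)c2)n1OCc1ccc(F)cc1`, which has the same atoms as compound 3, joined differently: 4-fluorophenyl in place of 2-fluorophenyl on a saturated chain carbon bound to an oxygen on an aromatic ring. Here 4-fluorophenyl stands in place of 2-fluorophenyl on a saturated chain carbon bound to an oxygen on an aromatic ring.

For the measured compounds named here, no measured pair compares these two groups directly. The closest evidence is the step at the same place, where exchanging vinyl for 2-fluorophenyl gave a 1.5-fold higher number from compound 2 to compound 3 (0.19 log units; within the scatter). The modest steps of a 3.8-fold lower number from compound 1 to compound 2 (0.58 log units; beyond the scatter) and a 2.5-fold lower number from compound 1 to compound 3 (0.39 log units; beyond the scatter) both replace methyl on an aromatic nitrogen, a larger change than the one at issue here. A change beyond the scatter is therefore not expected.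

The expected result is a 1.1-fold lower number from compound 3 to compound 4 (0.05 log units; within the scatter). The estimate for compound 4 is 8000 nM, with an expected range from 4000 nM to 16000 nM.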

Compound 4, half-maximal inhibitory concentration: 5880 nM
Estimate against measurement, compound 4: 1.4-fold (0.13 log units) above, and the stated range covers the measured number.
By their numbers in this assay, from the lowest: compounds 2, 4 and 3 (each within the scatter of the next); then compound 1.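

In this assay, 4-fluorophenyl in place of 2-fluorophenyl gives a 1.5-fold lower number from compound 3 to compound 4 (0.18 log units; within the scatter) and so leaves the number within the scatter: at this place on the saturated chain carbon, the two fluorine isomers cannot be told apart. The (4-fluorobenzyl)oxy group also reads the same as the allyloxy group, with a 1.0-fold higher number from compound 2 to compound 4 (0.00 log units; within the scatter) as the printed step, so exchanging vinyl for either fluorophenyl group has not produced a change beyond the scatter. Against methyl on the aromatic nitrogen, a 3.8-fold lower number from compound 1 to compound 4 (0.58 log units; beyond the scatter) is a modest step beyond the scatter, which makes (4-fluorobenzyl)oxy the third group on that nitrogen, after allyloxy and (2-fluorobenzyl)oxy, to give a lower number than methyl. Nothing available here explains these numbers or the lack of a difference between the two fluorine isomers.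

Whether the fluorine matters at all remains open, since a plain benzyloxy group, with no fluorine on the ring, is not among the compounds shown. Going by these compounds, the other parts of the shared core also remain open, including what a carboxylic acid or an amide in place of the ethyl ester would do to the number in this assay and whether a longer chain on the oxygen would read any differently.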